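Swapping fluoro for methoxy on a pendant aryl group

The source may hold more compounds than are shown below. What is called first, only, known or untested is meant among the compounds shown, and "the series" means these compounds.

Measured compounds in a functional assay on MDA-MB-231 cells (Homo sapiens) for cytotoxicity, read by MTT assay, with a stated time of 72 h; on this read-out lower numbers stand for stronger inhibition and higher numbers for weaker inhibition:
- compound 1 `COc1ccc(-c2ccc(C)n2-c2ccc(-c3nc4ccccc4s3)cc2)cc1` gives 14800 nM
- compound 2 `COc1ccc(-c2ccc(C)n2-c2ccc(-c3nc4ccc(F)cc4s3)cc2)cc1` gives 19000 nM
- compound 3 `COc1ccc2nc(-c3ccc(-n4c(C)ccc4-c4ccc(F)cc4)cc3)sc2c1` gives 13800 nM

Compound 3 shows the lowest of the three numbers, yet its gap to compound 1 and to compound 2 lies within the scatter of this assay, so the three compounds cannot be told apart on these values.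

Compound 4 `COc1ccc(-c2ccc(C)n2-c2ccc(-c3nc4ccc(OC)cc4s3)cc2)cc1` has not been measured. It differs from compound 3 by methoxy in place of fluoro on an aromatic carbon. Going by the values given here, the only measured step, a 1.3-fold higher number from compound 1 to compound 2 (0.11 log units; within the scatter), concerns a different place and a different pair of groups, so it bears on this change only loosely; it shows that a small change on an aromatic carbon of this scaffold left the read-out in this assay unchanged beyond the scatter. Among the compounds with values here, with no closer precedent, no step beyond the scatter is expected here; the expected step is a 1.1-fold higher number from compound 3 to compound 4 (0.02 log units; within the scatter). Compound 4 is therefore estimated at 14500 nM, with a range from 7000 nM to 30000 nM.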

Compound 4, half-maximal inhibitory concentration: 12700 nM
The estimate for compound 4 lay 1.1-fold (0.06 log units) above the measured number; low and high end bracket the measured number.
By their numbers in this assay, from the lowest: compounds 4, 3, 1 and 2 (each within the scatter of the next).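

In this assay, the pendant aryl group now has a direct test: going from 4-fluorophenyl to 4-methoxyphenyl gives a 1.1-fold lower number from compound 3 to compound 4 (0.04 log units; within the scatter), so fluoro and methoxy cannot be told apart at this position. The other place on the core, which earlier had only a step from hydrogen to fluoro, now also carries methoxy, and that place too stays within the scatter, with a 1.5-fold lower number from compound 2 to compound 4 (0.17 log units; within the scatter) for methoxy in place of fluoro and a 1.2-fold lower number from compound 1 to compound 4 (0.07 log units; within the scatter) for methoxy in place of hydrogen. No supporting evidence is available to explain these results.

Still open is whether any group at this position can move the number beyond the scatter, since fluoro and methoxy are the only two shown there. An amine or a carboxylic acid on the same aryl ring would test this more sharply.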